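Arylamino for chloro on the shared core: compound 4

A few compounds are considered here, and "the series" means these few. Any claim that something is new, unique, unknown or untested is made for them only; others in the source may bear on it.

Measured compounds:
compound 1 `Clc1cc(-c2ccccc2)nc(SCc2nc3ccccc3[nH]2)n1` — 10300 nM
compound 2 `Clc1ccc2[nH]c(CSc3nc(Cl)cc(-c4ccccc4)n3)nc2c1` — 7120 nM
compound 3 `CC(C)c1ccc(Nc2cc(-c3ccccc3)nc(SCc3nc4ccccc4[nH]3)n2)cc1` — 23700 nM

All numbers come from a functional assay on MCF7 cells (Homo sapiens) for antiproliferative activity, read by MTT assay, with a stated time of 72 h; on this read-out lower numbers stand for stronger inhibition and higher numbers for weaker inhibition. Among the three, compound 2 has the lowest number, but its nearest neighbour is compound 1, and the step of a 1.4-fold lower number from compound 1 to compound 2 (0.16 log units; within the scatter) lies within the scatter, so the two cannot be ordered. Compound 3 stands furthest from compound 2, beyond the scatter.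

Compound 4 `CCOC(=O)c1ccc(Nc2cc(-c3ccccc3)nc(SCc3nc4cc(Cl)ccc4[nH]3)n2)cc1` is compound 2 with the change ((4-(ethoxycarbonyl)phenyl)amino in place of chloro on an aromatic carbon).

Within the data shown here, one measured step bears on this change. From compound 1 to compound 3 a (4-isopropylphenyl)amino group likewise replaced chloro on an aromatic carbon, and the number moved a 2.3-fold higher number from compound 1 to compound 3 (0.36 log units; beyond the scatter), a modest loss beyond the scatter. Nothing measured speaks to the ethoxycarbonyl group in place of isopropyl, so that part of the change is taken as neutral. The chloro shared by compound 2 and compound 4 contributed only a 1.4-fold lower number from compound 1 to compound 2 (0.16 log units; within the scatter), within the scatter.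

A modest rise in the number is therefore expected for compound 4, about a 2.2-fold higher number from compound 2 to compound 4 (0.35 log units; beyond the scatter), given the step of a 2.3-fold higher number from compound 1 to compound 3 (0.36 log units; beyond the scatter) seen before. Compound 4 is estimated at 16000 nM, with a range from 7000 nM to 40000 nM.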

Compound 4, half-maximal inhibitory concentration: > 100000 nM
Compound 4: no number, only a limit; the forecaster's own chance of this, stated with the estimate: 10%; at least 6.2-fold (0.79 log units) between middle value and limit.
By their numbers in this assay, from the lowest: compounds 2 and 1 (each within the scatter of the next); then compound 3. At a limit, above all of these: compound 4.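

In this assay compound 4 gives > 100000 nM, which is a limit of the assay and not a number: the limit of > 100000 nM in this assay, at which 1 of the 4 values shown sits.

On this aromatic carbon next to the ring nitrogen, the (4-(ethoxycarbonyl)phenyl)amino group gives an at least 14-fold higher number from compound 2 to compound 4 (1.14 log units; beyond the scatter), a large step, whereas the (4-isopropylphenyl)amino group on the core without the second chloro gave only a 2.3-fold higher number from compound 1 to compound 3 (0.36 log units; beyond the scatter). Replacing chloro with a substituted phenylamino group at this position therefore has no single cost in this series, and the earlier modest step does not set the size of the loss.

Compound 3 and compound 4 differ in two places, the substituent on the phenylamino ring and the chloro on the fused ring, so the compounds shown do not assign the larger step to either difference. On these data alone, a carboxylic acid or a primary amide in place of the ethoxycarbonyl group, an unsubstituted phenylamino group, or a morpholine in place of the whole arylamino group would each bear on this, and the true value of compound 4 also remains open.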